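The source may report more compounds than this note shows. Statements on the series, on what has been measured and on what is new or still open speak of the compounds shown alone.

Measured so far in a functional assay on HCT-116 cells (Homo sapiens) for antiproliferative activity, read by MTT assay, with a stated time of 24 h; on this read-out lower numbers stand for stronger inhibition and higher numbers for weaker inhibition:

compound 1, `O=C1NC(O)(CCn2cc(C3=CCCCC3)nn2)C(OCc2ccccc2)=C1OCc1ccccc1`: > 100000 nM, a limit of this assay, not a number
compound 2, `CC(C)(C)c1ccc(-c2cn(C/C=C3\OC(=O)C(OCc4ccccc4)=C3OCc3ccccc3)nn2)cc1`: > 100000 nM, a limit of this assay, not a number
compound 3, `O=C1NC(O)(CCn2cc(Cc3ccccc3)nn2)C(OCc2ccccc2)=C1OCc1ccccc1`: 51200 nM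

Compound 2 therefore stands at the top of this assay's range; its value is a limit and gives no number to work from. Compound 3 is the only one of the three with a measured number, and it sits far up the scale.

The next compound, compound 4, `O=C1O/C(=C\Cn2cc(C3=CCCCC3)nn2)C(OCc2ccccc2)=C1OCc1ccccc1`, is reached from compound 2 by cyclohex-1-en-1-yl in place of 4-(tert-butyl)phenyl on an aromatic carbon. Within the data shown here, the only measured step that touches the cyclohex-1-en-1-yl group is an at least 1.9-fold lower number from compound 1 to compound 3 (0.29 log units; that floor lies within the scatter), which runs from a limit to a number on the other core and is of a size that lies within the scatter. In the present step the cyclohex-1-en-1-yl group enters rather than leaves, so that step gives no reason to expect a lower number; with compound 2 already at the limit of > 100000 nM in this assay, at which 2 of the 3 values shown sit, no change beyond the scatter is expected in this assay, and a limit is the likely outcome.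

For compound 4 the estimate is 150000 nM, within 60000 nM to 400000 nM. The expected step is a step that the limit leaves unreadable from compound 2 to compound 4.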

Compound 4, half-maximal inhibitory concentration: > 100000 nM
Compound 4: a limit, no number (the forecaster's own chance of this, stated with the estimate: 80%); the middle value is on the limit's open side.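

In this assay compound 4 stands at > 100000 nM as a limit, not a number. Among these compounds, compound 2 also gives only a limit, so no step between compound 2 and compound 4 can be read: the limit of > 100000 nM in this assay, at which 3 of the 4 values shown sit.

The compounds shown leave open whether cyclohex-1-en-1-yl and 4-(tert-butyl)phenyl differ at all on this core.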